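From 3-nitrophenyl to 4-nitrophenyl in the alkoxy series

A few compounds are considered here, and "the series" means these few. Any claim that something is new, unique, unknown or untested is made for them only; others in the source may bear on it.

Values in a functional assay on SK-N-MC cells (Homo sapiens) for cytotoxicity, read by MTT assay; a lower number here means a stronger inhibitor, a higher number a weaker inhibitor:
compound 1 `CCOc1c(Br)cc(/C=C2\CCC/C(=C\c3cccc([N+](=O)[O-])c3)C2=O)cc1OC`: 10.8 ug/mL
compound 2 `CCCOc1c(Br)cc(/C=C2\CCC/C(=C\c3cccc([N+](=O)[O-])c3)C2=O)cc1OC`: 1.51 ug/mL
compound 3 `CCCCOc1c(Br)cc(/C=C2\CCC/C(=C\c3cccc([N+](=O)[O-])c3)C2=O)cc1OC`: 25.4 ug/mL

Compound 3 holds the highest number of the three. Compound 4 `CCCCOc1c(Br)cc(/C=C2\CCC/C(=C\c3ccc([N+](=O)[O-])cc3)C2=O)cc1OC` has the same atoms joined differently: 4-nitrophenyl in place of 3-nitrophenyl on a double-bonded chain carbon bound to a double-bonded ring carbon. Within the data shown here, no measured step touches this group. The measured steps, a 7.2-fold lower number from compound 1 to compound 2 (0.85 log units; beyond the scatter) and a 17-fold higher number from compound 2 to compound 3 (1.23 log units; beyond the scatter) and a 2.4-fold higher number from compound 1 to compound 3 (0.37 log units; beyond the scatter), all change the chain on the aromatic oxygen. They bear on the new change only indirectly, showing that a single change in this series can move the number in this assay by a modest or a large step. The data give neither size nor direction for the move to 4-nitrophenyl. The central expectation in this assay is therefore no step beyond the scatter, with a slight lean to a lower number only in that compound 3 at 25.4 ug/mL stands at the top of the three. The expected step is a 1.7-fold lower number from compound 3 to compound 4 (0.23 log units; within the scatter) and it remains uncertain. For compound 4 the estimated value is 15 ug/mL with an expected range from 4 ug/mL to 55 ug/mL in this assay.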

Compound 4, half-maximal inhibitory concentration: 41.3 ug/mL
Estimate against measurement, compound 4: 2.8-fold (0.44 log units) below; the range from low to high includes it.
By their numbers in this assay, from the lowest: compound 2; then compound 1; then compounds 3 and 4 (each within the scatter of the next).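

In this assay, 4-nitrophenyl in place of 3-nitrophenyl on a double-bonded chain carbon bound to a double-bonded ring carbon gives a 1.6-fold higher number from compound 3 to compound 4 (0.21 log units; within the scatter), so with the butyl chain on the aromatic oxygen, this change cannot be told apart from repeat measurement. The chain on that oxygen therefore remains the only place in this set where a change has been seen to move the number beyond the scatter, as in a 17-fold higher number from compound 2 to compound 3 (1.23 log units; beyond the scatter), whereas the nitrophenyl change has not. No supporting data offer an account of this result.

From the compounds shown here alone, whether the same holds on the propyl chain of compound 2, at 1.51 ug/mL, stays open. Also open, going by these compounds, is what an amine in place of the nitro group would do at this place.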